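The source may report more compounds than this note shows. Statements on the series, on what has been measured and on what is new or still open speak of the compounds shown alone.

Measured so far:
compound 1, `NC[C@@H]1CCCc2cc(S(=O)(=O)c3cc(F)cc4[nH]cnc34)ccc21`: 5.01 nM
compound 2, `O=S(=O)(c1cccc(F)c1)c1ccc2c(c1)CCC[C@H]2CNCCO`: 0.126 nM

Both compounds were tested in an assay on isolated protein for displacement of a labelled ligand from 5-hydroxytryptamine receptor 6 (Homo sapiens); on this read-out higher numbers stand for weaker inhibition and lower numbers for stronger inhibition. Compound 2 gives the lower of the two numbers, and compound 1, at 5.01 nM, lies far above it, well beyond the scatter of repeat measurements. Compound 3, `CS(=O)(=O)NC[C@@H]1CCCc2cc(S(=O)(=O)c3cccc(F)c3)ccc21`, has not yet been measured in this assay. It differs from compound 2 in one place: methylsulfonyl in place of 2-hydroxyethyl on an amine nitrogen. Among the compounds with values here, no pair of measured compounds shows a step of this kind, so there is no directly comparable step to lean on. Because compound 2 stands so low at 0.126 nM, the expected movement for compound 3 is upward, toward a weaker result, and the estimated step is a 400-fold higher number from compound 2 to compound 3 (2.60 log units; beyond the scatter). For compound 3 in this assay the estimate is 50 nM, expected to fall between 5 nM and 500 nM.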

Compound 3, inhibition constant: 0.2 nM
Estimate against measurement, compound 3: 250-fold (2.40 log units) above; measured number below the stated range.
By their numbers in this assay, from the lowest: compounds 2 and 3 (each within the scatter of the next); then compound 1.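

Swapping 2-hydroxyethyl for methylsulfonyl on an amine nitrogen amounts in this assay to a 1.6-fold higher number from compound 2 to compound 3 (0.20 log units; within the scatter), so the two compounds cannot be told apart on this read-out. This is the first step shown at this nitrogen, and it indicates that the position accepts two quite different groups without a change beyond the scatter. The group that leaves has 1 hydrogen-bond donor and 1 hydrogen-bond acceptor, the one that enters has 0 hydrogen-bond donors and 2 hydrogen-bond acceptors, and no evidence is available on why the two read alike.

The compounds shown leave open whether an acetyl group, an ethylsulfonyl group or a phenylsulfonyl group on this nitrogen would read the same way. They also leave open whether methylsulfonyl would behave alike on the core of compound 1.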